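A Methoxy Group Becomes Hydroxy on the Shared Core

The source may hold more compounds than are shown below. What is called first, only, known or untested is meant among the compounds shown, and "the series" means these compounds.

In a functional assay on HT-1080 cells (Homo sapiens) for cytotoxicity, read by MTT assay, with a stated time of 72 h (a higher number here means a weaker inhibitor, a lower number a stronger inhibitor), compound 1 `COc1cccc(/C=C2\CCC/C(=C\c3ccc(OC)c(OC)c3)C2=O)c1` gives 4600 nM and compound 2 `COc1ccc(/C=C2\CCC/C(=C\c3ccc(OC)c(OC)c3)C2=O)cc1OC` gives 3000 nM, two numbers within the scatter of each other. For the measured compounds named here, compound 2 therefore stands level with the only other compound measured. Compound 3 `COc1cc(/C=C2\CCC/C(=C\c3ccc(OC)c(OC)c3)C2=O)ccc1O` differs from compound 2 by hydrogen in place of methyl on an oxygen on an aromatic ring, which reads as methoxy to hydroxy. Going by the values given here, the sole measured step, a 1.5-fold lower number from compound 1 to compound 2 (0.19 log units; within the scatter), put methoxy in place of hydrogen on an aromatic carbon and stayed within the scatter. It is a different change, so it offers only a weak guide, and no shift beyond the scatter is expected in this assay. The expected step is a 1.2-fold lower number from compound 2 to compound 3 (0.08 log units; within the scatter). Compound 3 is expected at 2500 nM, with an estimated range of 1000 nM to 6000 nM.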

Compound 3, half-maximal inhibitory concentration: 4600 nM
The estimate for compound 3 lay 1.8-fold (0.26 log units) below the measured number; measured number inside the range.
By their numbers in this assay, from the lowest: compounds 2, 1 and 3 (each within the scatter of the next).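

In this assay the move from methoxy to hydroxy gives a 1.5-fold higher number from compound 2 to compound 3 (0.19 log units; within the scatter) while putting a hydroxy where a hydrogen stood gives no change at the digits printed from compound 1 to compound 3 (within the scatter) and both steps stay within the scatter. Hydrogen, methoxy and hydroxy at this one place on the aromatic ring therefore read alike across these three compounds, so a free hydroxy joins the two groups already seen there without moving the number beyond the scatter. On these data alone, whether an amine or a carboxylic acid at this place would do the same remains open. Nothing available explains why these three compounds read alike.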